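Furan to methoxyphenyl swap in the acrylonitrile amide series

The source may report more compounds than this note shows. Statements on the series, on what has been measured and on what is new or still open speak of the compounds shown alone.

Compound 1 `N#C/C(=C\c1c[nH]c2ccccc12)C(=O)c1c[nH]c2ccccc12` gives 8300 nM in a functional assay on SW480 cells (Homo sapiens) for inhibition, read by MTT assay, with a stated time of 72 h; on this read-out lower numbers stand for stronger inhibition of growth and higher numbers for weaker inhibition of growth. Compound 3 `COc1ccc(CNC(=O)/C(C#N)=C/c2ccc(C)o2)cc1` gives 29000 nM in this assay. For compound 2 `N#C/C(=C\c1ccco1)C(=O)NCc1ccc(Cl)c(Cl)c1` only a limit is recorded in this assay, > 50000 nM, which places it at the limit of > 50000 nM in this assay, at which 1 of the 3 values shown sits. Compound 4 `COc1ccc(/C=C(\C#N)C(=O)NCc2ccc(Cl)c(Cl)c2)cc1` is not yet measured; it differs from compound 2 by 4-methoxyphenyl in place of furan-2-yl on a double-bonded chain carbon bound to a double-bonded chain carbon. Within the data shown here, no measured pair isolates this change; compound 3 keeps a furan and carries its methoxy on the amide side instead. The expected step of an at least 1.4-fold lower number from compound 2 to compound 4 (0.15 log units; that floor lies within the scatter) is small and toward stronger inhibition, possibly not beyond the scatter, and a further limit remains likely. Compound 4 is estimated at 35000 nM in this assay, within 10000 nM to 100000 nM.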

Compound 4, concentration for 50% growth inhibition: 95000 nM
Beside the measured number, compound 4's estimate is 2.7-fold (0.43 log units) below it, within the range that was stated.
By their numbers in this assay, from the lowest: compound 1; then compound 3; then compound 4.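

No step from compound 2 to compound 4 can be read in this assay, since compound 2 carries only a limit: the limit of > 50000 nM in this assay, at which 1 of the 4 values shown sits.

The compounds shown leave open the size and direction of the effect of 4-methoxyphenyl in place of furan-2-yl.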